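A few compounds are considered here, and "the series" means these few. Any claim that something is new, unique, unknown or untested is made for them only; others in the source may bear on it.

Measured so far in a functional assay on PC-3 cells (Homo sapiens) for cytotoxicity, read by MTT assay, with a stated time of 72 h; a higher number here means a weaker inhibitor, a lower number a stronger inhibitor:
- compound 1 `COc1cc(Nc2nc3ccccc3nc2S(=O)(=O)c2ccc(C)cc2)cc(OC)c1` gives 2940 nM
- compound 2 `Cc1ccc(S(=O)(=O)c2nc3ccccc3nc2Nc2cccc(O)c2)cc1` gives 1690 nM

Compound 2 and compound 1 lie within the scatter of each other in this assay; the step of a 1.7-fold lower number from compound 1 to compound 2 (0.24 log units; within the scatter) is the only one recorded. Compound 3 `O=S(=O)(c1ccc(Br)cc1)c1nc2ccccc2nc1Nc1cccc(O)c1` differs from compound 2 by bromo in place of methyl on an aromatic carbon. For the measured compounds named here, no measured step touches this change on the 4-methylphenyl; the one step recorded concerns the other aromatic ring and is itself within the scatter. Nothing here supports a shift beyond the scatter in this assay. Compound 3 is therefore estimated at 1700 nM, range 600 nM to 4800 nM, an expected step of a 1.0-fold higher number from compound 2 to compound 3 (0.00 log units; within the scatter).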

Compound 3, half-maximal inhibitory concentration: 1700 nM
Beside the measured number, compound 3's estimate shows no gap at the digits printed, within the range that was stated.
By their numbers in this assay, from the lowest: compounds 2, 3 and 1 (each within the scatter of the next).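

In this assay, for the compounds shown here, the change from 4-methylphenyl to 4-bromophenyl, the only step recorded at this ring, reads a 1.0-fold higher number from compound 2 to compound 3 (0.00 log units; within the scatter) with the 3-hydroxyphenyl held constant. This aromatic carbon, para to a large group, therefore takes bromo in place of methyl with no shift beyond the scatter. No supporting data bear on why the two groups read alike.

As far as these compounds go, whether an amine, a carboxylic acid or a longer chain at this carbon would move the number beyond the scatter remains open. No step beyond the scatter has yet appeared at either aromatic ring.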